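A few compounds are considered here, and "the series" means these few. Any claim that something is new, unique, unknown or untested is made for them only; others in the source may bear on it.

Compound 1 `COc1cc(COCc2cn(Cc3cc(-c4ccccc4)cnc3Cl)nn2)cc(OC)c1OC` gives 45500 nM in a functional assay on DU-145 cells (Homo sapiens) for cytotoxicity, read by MTT assay, with a stated time of 48 h (on this read-out lower numbers stand for stronger inhibition and higher numbers for weaker inhibition), compound 2 `COc1cc(COCc2cn(Cc3cc(-c4ccc(F)cc4)cnc3Cl)nn2)cc(OC)c1OC` gives 38800 nM in this assay, and compound 3 `COc1cc(-c2cc(COCc3cn(Cc4cc(-c5ccc(F)cc5)cnc4Cl)nn3)on2)cc(OC)c1OC` gives 31900 nM in this assay. The number for compound 3 is the lowest of the three, yet its gaps to compound 2 and to compound 1 both fall within the scatter of repeated measurements, so the three compounds cannot be told apart on these numbers. Compound 4 `COc1cc(-c2cc(COCc3cn(Cc4cc(-c5ccccc5)cnc4Cl)nn3)on2)cc(OC)c1OC` has not yet been measured. The change from compound 3 to compound 4 is hydrogen in place of fluoro on an aromatic carbon. Among the compounds with values here, one measured step bears on it and runs the same change the other way: a 1.2-fold lower number from compound 1 to compound 2 (0.07 log units; within the scatter). Because that step was within the scatter, no movement beyond the scatter is expected here either. For compound 4 the expected step is a 1.1-fold higher number from compound 3 to compound 4 (0.05 log units; within the scatter). Compound 4 is therefore estimated at 36000 nM in this assay, with a range from 18000 nM to 72000 nM.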

Compound 4, half-maximal inhibitory concentration: 78500 nM
Beside the measured number, compound 4's estimate is 2.2-fold (0.34 log units) below it, and the stated range ends below it.
By their numbers in this assay, from the lowest: compounds 3, 2, 1 and 4 (each within the scatter of the next, the first and the last beyond it).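

The core of compound 3 shows a 2.5-fold higher number from compound 3 to compound 4 (0.39 log units; beyond the scatter) when 4-fluorophenyl becomes phenyl, so on this core the fluoro at this position, para to a large group, makes a difference in this assay that can be told from the scatter. The pair of compound 1 and compound 2 could not show this, as their step stayed within the scatter. Even so, the step is modest, and the two cores cannot be said to respond differently to this change: the same change on two cores in this assay, a 1.2-fold lower number (0.07 log units; within the scatter) from compound 1 to compound 2 and a 2.5-fold lower number (0.39 log units; beyond the scatter) from compound 4 to compound 3, 2.1-fold (0.32 log units) apart, within the scatter of two such steps.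

The compounds shown carry only hydrogen or fluoro at this position, so it remains open how a chloro, a methoxy or an amine there would read. As far as these compounds go, whether any group at this position could bring these numbers down much further also remains open.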